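This account rests on a few compounds, and the source may have more. Where it says the series, first, only, none or still open, it means among the compounds named here.

Working notes on the indazolyl urea series.

Three compounds have numbers in a functional assay for antagonist activity at transient receptor potential cation channel subfamily V member 1 (Homo sapiens), read by calcium flux; a higher number here means a weaker inhibitor, a lower number a stronger inhibitor. Compound 1 `COc1ccc2c(c1)C(NC(=O)Nc1cccc3[nH]ncc13)CCN2C` gives 1380 nM in this assay. Compound 2 `O=C(Nc1cccc2[nH]ncc12)NC1CCN(Cc2ccccc2)c2ccc(F)cc21` gives 66 nM in this assay. Compound 3 `CC(C)(C)c1ccc2c(c1)C(NC(=O)Nc1cccc3[nH]ncc13)CCN2Cc1ccccc1` gives 121 nM in this assay, which places it second highest of the three: compound 2 is nearest, with a number below it but within the scatter, and compound 1 is furthest, with a number well above it. Within the data shown here, the one single-point step among the measured compounds is a 1.8-fold higher number from compound 2 to compound 3 (0.26 log units; within the scatter), so the swap of fluoro for tert-butyl on the aromatic carbon does not move the number beyond the scatter.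

Compound 4 `COc1ccc2c(c1)C(NC(=O)Nc1cccc3[nH]ncc13)CCN2Cc1ccccc1` is not yet measured. It differs from compound 3 in one place: methoxy in place of tert-butyl on an aromatic carbon. Among the measured compounds shown here, the step from compound 2 to compound 3 is the only one that bears on this position, and it was small; no step from tert-butyl to methoxy has been measured here. Compound 1 carries methoxy at the same place but with methyl rather than benzyl on the ring nitrogen, so its number is not a direct guide. For compound 4 a step of about a 1.1-fold higher number from compound 3 to compound 4 (0.03 log units; within the scatter) in this assay is therefore expected, that is, no move beyond the scatter. Compound 4 is estimated at 130 nM, with a range from 45 nM to 400 nM.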

Compound 4, half-maximal inhibitory concentration: 160 nM
Estimate against measurement, compound 4: 1.2-fold (0.09 log units) below; low and high end bracket the measured number.
By their numbers in this assay, from the lowest: compounds 2, 3 and 4 (each within the scatter of the next, the first and the last beyond it); then compound 1.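

Working notes, continued. In this assay, methoxy and tert-butyl on this aromatic carbon cannot be told apart (a 1.3-fold higher number from compound 3 to compound 4 (0.12 log units; within the scatter)), so this position accepts either group within the scatter, even though only methoxy brings a hydrogen-bond acceptor. Fluoro gives a slightly sharper reading: methoxy in place of fluoro lies just beyond the scatter (a 2.4-fold higher number from compound 2 to compound 4 (0.38 log units; beyond the scatter)), while tert-butyl in place of fluoro stays within it (a 1.8-fold higher number from compound 2 to compound 3 (0.26 log units; within the scatter)), so any preference for fluoro over the two larger groups is modest and rests on compound 2 alone. With methoxy held fixed, the change on the ring nitrogen from methyl to benzyl, printed as phenyl in place of hydrogen on a saturated chain carbon (an 8.6-fold lower number from compound 1 to compound 4 (0.94 log units; beyond the scatter)), is much larger than either change on the aromatic carbon, so in these compounds the ring nitrogen substituent moves the number more than this position does.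

No measurement at hand explains any of these steps. Still open, from the compounds shown here alone, is whether an amine or a carboxylic acid on this aromatic carbon, or a longer chain on the ring nitrogen, would stay in the range of compounds 2, 3 and 4.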